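Replacing One Aryl Group on Compound 2

The source may report more compounds than this note shows. Statements on the series, on what has been measured and on what is new or still open speak of the compounds shown alone.

In a functional assay on A549 cells (Homo sapiens) for inhibition, read by MTT assay, with a stated time of 72 h (on this read-out higher numbers stand for weaker inhibition and lower numbers for stronger inhibition), compound 1 `COc1cc2c(Oc3ccc(NC(=O)c4nn(-c5ccccc5C(F)(F)F)ccc4=O)cc3)ccnc2cc1OCC(=O)NO` gives > 20000 nM as a limit, not a number. Going by the values given here, compound 2 `COc1cc2c(Oc3ccc(NC(=O)c4nn(-c5ccc(Cl)c(C(F)(F)F)c5)cc(C)c4=O)cc3)ccnc2cc1OCC(=O)NO` gives 1590 nM as the only true number so far. Compound 3 `COc1cc2c(Oc3ccc(NC(=O)c4nn(-c5ccccc5C)cc(C)c4=O)cc3)ccnc2cc1OCC(=O)NO` differs from compound 2 in one place (2-methylphenyl in place of 4-chloro-3-(trifluoromethyl)phenyl on an aromatic nitrogen) with 2-methylphenyl in place of 4-chloro-3-(trifluoromethyl)phenyl on an aromatic nitrogen. Among the compounds with values here, no measured pair isolates this change. Starting from compound 2 at 1590 nM a moderate weakening is expected in this assay on thin evidence. The estimated change a 2.8-fold higher number from compound 2 to compound 3 (0.45 log units; beyond the scatter) is expected to lie beyond the usual scatter. Compound 3 is expected at 4500 nM with a likely range from 1300 nM to 18000 nM as an estimate.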

Compound 3, half-maximal inhibitory concentration: 5980 nM
The estimate for compound 3 lay 1.3-fold (0.12 log units) below the measured number; low and high end bracket the measured number.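

In this assay, this position now has its first readable step, a 3.8-fold higher number from compound 2 to compound 3 (0.58 log units; beyond the scatter), so the group on the aromatic nitrogen can shift the number beyond the scatter. Both compounds give true numbers, so with 2-methylphenyl in place of 4-chloro-3-(trifluoromethyl)phenyl, inhibition weakens but remains measurable. Compound 1 remains a limit and not a number: the limit of > 20000 nM in this assay, at which 1 of the 3 values shown sits.

From the compounds shown here alone, this single step changes the chlorine, the trifluoromethyl and the methyl together, so the share of each stays open. Going by these compounds, how a phenyl ring carrying an amine or a carboxylic acid would read here also stays open.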